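Ring Opened at the Amine: Compound 1 to Compound 4

The source may report more compounds than this note shows. Statements on the series, on what has been measured and on what is new or still open speak of the compounds shown alone.

Measured compounds in this assay:
compound 1, `O=c1[nH]c(-c2cccc3ccccc23)nc2ccc(N3CCCCC3)cc12`: 330 nM
compound 2, `Cc1ccc2c(=O)[nH]c(-c3ccccc3N(C)C)nc2c1`: 43800 nM
compound 3, `Cc1ccc2c(=O)[nH]c(-c3cccc(OC(F)(F)F)c3)nc2c1`: > 50000 nM (a limit of the assay)

In a functional assay on HeLa cells (Homo sapiens) for cytotoxicity, read by MTT assay, with a stated time of 2 days (on this read-out lower numbers stand for stronger inhibition and higher numbers for weaker inhibition), compound 1 gives 330 nM, the lowest of the two numbers shown. The nearest number belongs to compound 2, which gives 43800 nM, a far higher figure and well beyond the scatter of repeated measurements. Compound 3 does not yield a number at all; it sits at the limit of > 50000 nM in this assay, at which 1 of the 3 values shown sits.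

Compound 4, `CCN(CC)c1ccc2nc(-c3cccc4ccccc34)[nH]c(=O)c2c1`, differs from compound 1 in a single place: diethylamino in place of piperidin-1-yl on an aromatic carbon. Among the compounds with values here, no measured pair in this set changes one group for another in the same way, so there is no comparable step to lean on. The two amines are of similar size and carry the same count of acceptors, and the core is unchanged, so the author expects a step from compound 1 that stays within the usual scatter, or is at most a modest rise in the number.

Compound 4 is therefore estimated to give 500 nM, within a range of 150 nM to 2000 nM. The expected step is a 1.5-fold higher number from compound 1 to compound 4 (0.18 log units; within the scatter), judged not to exceed the scatter by much, if at all.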

Compound 4, half-maximal inhibitory concentration: 4 nM
For compound 4 the middle estimate is 130-fold (2.10 log units) above the measured one; measured number outside the range, below it.
By their numbers in this assay, from the lowest: compound 4; then compound 1; then compound 2. At a limit, above all of these: compound 3.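

In this assay, diethylamino in place of piperidin-1-yl on this aromatic carbon is far from a neutral exchange: it gives an 83-fold lower number from compound 1 to compound 4 (1.92 log units; beyond the scatter). Within the data shown here, the earlier compounds offered no pair differing in one place, and this step is the first to show that the read-out is sensitive to the form of the amine here, even though the two groups have the same counts of hydrogen-bond donors and acceptors and neither carries a net charge. Nothing measured here gives a reason for the step.

As far as these compounds go, what remains open is whether the open chains themselves matter or only the loss of this particular ring. Dimethylamino, dipropylamino, pyrrolidin-1-yl or morpholin-4-yl on the same carbon would show how far the step extends.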